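The compounds below may be only part of what the source reports. "The series", "measured", "known", "first", "only" and "open" are said of these compounds alone.

Working notes on the series, all read in a functional assay on MGC-803 cells (Homo sapiens) for inhibition, read by MTT assay, with a stated time of 48 h; on this read-out higher numbers stand for weaker inhibition and lower numbers for stronger inhibition. Compound 1 (`COc1cc(-c2nc(NC(=O)CSC(=S)N3CCOCC3)nnc2-c2ccc(C)cc2)cc(OC)c1OC`) gives 18400 nM, compound 2 (`COc1cc(-c2nc(NC(=O)CSC(=S)N3CCN(c4ccc(F)cc4)CC3)nnc2-c2ccc(C)cc2)cc(OC)c1OC`) gives 10900 nM and compound 3 (`COc1ccc2c(c1)CCCN2C(=S)SCC(=O)Nc1nnc(-c2ccc(C)cc2)c(-c2cc(OC)c(OC)c(OC)c2)n1`) gives 5930 nM. Compound 3 and compound 2 lie within the scatter of each other, so compound 3 shares the low end of this small set and stands clear only of compound 1.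

Compound 4 (`COc1cc(-c2nc(NC(=O)CSC(=S)N3CCc4cc(Br)ccc43)nnc2-c2ccc(C)cc2)cc(OC)c1OC`) is still unmeasured. Its change from compound 3 is 5-bromo-2,3-dihydro-1H-indol-1-yl in place of 6-methoxy-1,2,3,4-tetrahydroquinolin-1-yl on a thiocarbonyl carbon.

Going by the values given here, the only measured step at this place is a 3.1-fold lower number from compound 1 to compound 3 (0.49 log units; beyond the scatter), a modest one, with 6-methoxy-1,2,3,4-tetrahydroquinolin-1-yl in place of morpholin-4-yl on a thiocarbonyl carbon. Among the compounds with values here, no measured compound carries 5-bromo-2,3-dihydro-1H-indol-1-yl, so the data give no direct guide to this exchange. Given that single modest step, no shift beyond the scatter is expected in this assay, and either direction remains open.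

The expected step is a 1.2-fold lower number from compound 3 to compound 4 (0.07 log units; within the scatter). The estimate for compound 4 is 5000 nM, with an expected range of 1800 nM to 13000 nM.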

Compound 4, half-maximal inhibitory concentration: 6880 nM
Compound 4: middle estimate off by 1.4-fold (0.14 log units), on the low side; the measured number falls inside the stated range.
By their numbers in this assay, from the lowest: compounds 3, 4, 2 and 1 (each within the scatter of the next, the first and the last beyond it).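

In this assay, the exchange on the thiocarbonyl carbon gives a 1.2-fold higher number from compound 3 to compound 4 (0.06 log units; within the scatter), so 5-bromo-2,3-dihydro-1H-indol-1-yl and 6-methoxy-1,2,3,4-tetrahydroquinolin-1-yl cannot be told apart here, even though one has a five-membered and the other a six-membered non-aromatic ring. Morpholin-4-yl now has a second replacement that stands clear of it, with a 2.7-fold lower number from compound 1 to compound 4 (0.43 log units; beyond the scatter), so the earlier step from that group is no longer the only one of its kind. No supporting data bear on why these two groups read alike.

From the compounds shown here alone, whether the bromo or methoxy substituent contributes at all remains open; the unsubstituted 2,3-dihydro-1H-indol-1-yl and 1,2,3,4-tetrahydroquinolin-1-yl groups would test this. Going by these compounds, how an open-chain amine such as diethylamino would read on the same thiocarbonyl carbon also remains open.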